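Triazolothiadiazole series: aryl swap at the thiadiazole carbon

This account rests on a few compounds, and the source may have more. Where it says the series, first, only, none or still open, it means among the compounds named here.

Measured so far:
compound 1, `CCc1nn2c(C(C)c3ccc(CC(C)C)cc3)nnc2s1`: 45%
compound 2, `CC(C)Cc1ccc(C(C)c2nnc3sc(-c4ccc(Br)cc4)nn23)cc1`: 64%

In a functional assay on the whole organism (strain Wistar albino) for inhibition, with Rattus norvegicus as the target, read by paw edema, with stated times of 30 min and 2 h, at a dose of 20 mg/kg by the oral route (on this read-out higher numbers stand for more inhibition at the one dose given (going by the name of the read-out) and lower numbers for less inhibition), compound 1 gives 45% and compound 2 gives 64%. Going by the values given here, the one measured step, a number 19 percentage points higher from compound 1 to compound 2 (beyond the scatter), runs in the direction of more inhibition when an aromatic ring replaces the ethyl chain at the aromatic carbon of the shared core. Among the compounds with values here, compound 2 thus holds the higher of the two numbers, with compound 1 the only neighbour and standing beyond the scatter below it.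

Compound 3, `CC(C)Cc1ccc(C(C)c2nnc3sc(-c4ccc([N+](=O)[O-])cc4Cl)nn23)cc1`, is not yet measured. Its change from compound 2 is 2-chloro-4-nitrophenyl in place of 4-bromophenyl on an aromatic carbon. Within the data shown here, no measured step exchanges one aromatic ring for another at this position; the only step known, a number 19 percentage points higher from compound 1 to compound 2 (beyond the scatter), speaks to the presence of an aromatic ring there, not to which substituents it carries. Since an aromatic ring is retained in compound 3, the expected step of a number 2 percentage points lower from compound 2 to compound 3 (within the scatter) is none beyond the scatter, with the direction left open. Compound 3 is therefore estimated at 62% in this assay, in the range 45% to 78%.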

Compound 3, a percentage reported as inhibition, in the whole organism at one dose (the size of the read-out at that dose, not a potency): 67%
Compound 3: the middle estimate sits 5 percentage points below what was measured; the measured number falls inside the stated range.
By their numbers in this assay, from the lowest: compound 1; then compounds 2 and 3 (each within the scatter of the next).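

Notes on the aryl group at the aromatic carbon of the five-membered ring: in this assay, 2-chloro-4-nitrophenyl in place of 4-bromophenyl gives a number 3 percentage points higher from compound 2 to compound 3 (within the scatter), so this exchange of one substituted phenyl ring for another, with its different ring substituents, does not separate the two compounds on this read-out. Relative to the ethyl group, the same 2-chloro-4-nitrophenyl group gives a number 22 percentage points higher from compound 1 to compound 3 (beyond the scatter), so both aryl compounds shown now stand clear of the ethyl compound, and neither of them goes against that reading. No supporting data on this result are available to account for either step.

As far as these compounds go, whether an aromatic ring is needed at this carbon remains open, as a cyclohexyl ring or a longer chain such as n-hexyl would test that directly in this assay. From the compounds shown here alone, it is also open whether the flat reading between the two aryl groups holds for other ring substituents, such as an amine or a carboxylic acid, and whether the chlorine and the nitro group would each read the same alone on the phenyl ring.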